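This account rests on a few compounds, and the source may have more. Where it says the series, first, only, none or still open, it means among the compounds named here.

Three compounds of the series have numbers in an ADME assay on microsomes from liver (Mus musculus) for metabolic stability, read by LC-MS, using NADPH, with stated times of 10 min and 30 min, tested at 1 uM; a higher number here means faster removal of the compound, a lower number slower removal. Compound 1 `COC(=O)C1=C(C)NC(c2nccs2)=NC1(C)c1ccc(Cl)cc1` gives 85 mL/min/kg in this assay. Compound 2 `COC(=O)C1=C(C)NC(c2nccs2)=NC1(C)c1ccc(C#N)cc1` gives 75 mL/min/kg. Going by the values given here, the one step that can be read between measured compounds, a 1.1-fold lower number from compound 1 to compound 2 (0.05 log units; within the scatter), lies within the scatter. Compound 3 `COC(=O)C1=C(CN2CCC(O)CC2)NC(c2nccs2)=NC1(C)c1ccc(F)cc1` gives 81 mL/min/kg; of the three numbers it stands second highest, with compound 1 nearest and compound 2 furthest, and both of these gaps lie within the scatter, so the three compounds cannot be told apart on this read-out.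

Compound 4 `COC(=O)C1=C(COCC(F)(F)F)NC(c2nccs2)=NC1(C)c1ccc(F)cc1` has not been measured in this assay. It differs from compound 3 in one place: 2,2,2-trifluoroethoxy in place of 4-hydroxypiperidin-1-yl on a saturated chain carbon bound to a double-bonded ring carbon. Among the compounds with values here, no measured step in the set involves a change at the saturated chain carbon bound to a double-bonded ring carbon; the only measured step concerns a change on an aromatic carbon and lies within the scatter. The measured set therefore offers nothing that points to a step beyond the scatter in either direction for this change, and nothing that rules one out. The step of no change at the digits printed from compound 3 to compound 4 (within the scatter) is expected to lie within the scatter. The estimate for compound 4 is 81 mL/min/kg, with a range from 45 mL/min/kg to 150 mL/min/kg.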

Compound 4, clearance: 81 mL/min/kg
Compound 4: the middle estimate sits on the measured number at the digits printed; the range from low to high includes it.
By their numbers in this assay, from the lowest: compounds 2, 3, 4 and 1 (each within the scatter of the next).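

In this assay, going by these compounds alone, putting 2,2,2-trifluoroethoxy in place of 4-hydroxypiperidin-1-yl on a saturated chain carbon bound to a double-bonded ring carbon gives no change at the digits printed from compound 3 to compound 4 (within the scatter) and is the first step read at this position. The exchange is not a small one on paper: the ring, the nitrogen and the hydrogen-bond donor of 4-hydroxypiperidin-1-yl all leave, three fluorines enter, and still this read-out does not separate the two compounds, so for this one pair the group on the chain carbon makes no difference beyond the scatter. Nothing at hand bears on why the number holds across so large an exchange of atoms.

On these data alone, whether any group at this position can move the number beyond the scatter stays open, since a single pair cannot show it, and a carboxylic acid, a morpholine or a longer ether chain on the same saturated chain carbon could behave differently. Also open, as far as these compounds go, is whether the high numbers of the series depend on parts shared by all the compounds, such as the methyl ester, which an amide in its place would test.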